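Swapping a carbamoylphenyl group for a triazole at the thioether

The source may hold more compounds than are shown below. What is called first, only, known or untested is meant among the compounds shown, and "the series" means these compounds.

Compound 1 `N#Cc1c(N)nc(SCc2cccc(C(N)=O)c2)c(C#N)c1-c1ccc(OCC2CC2)cc1` gives 12.7 nM in a functional assay on CHO cells for agonist activity at adenosine receptor A2b (Homo sapiens), read by AlphaScreen and cAMP accumulation; a higher number here means that more compound is needed for the effect, a lower number that less compound is needed. Compound 2 `CCOc1ccc(-c2c(C#N)c(N)nc(SCC(N)=O)c2C#N)cc1` gives 38 nM in this assay.

Of these two numbers, compound 1 has the lower one, and compound 2 sits a step above it that is beyond the usual scatter. Compound 3 `N#Cc1c(N)nc(SCc2ncn[nH]2)c(C#N)c1-c1ccc(OCC2CC2)cc1` keeps the core of compound 1 and changes only the group hanging from the sulfur: 1H-1,2,4-triazol-5-yl in place of 3-carbamoylphenyl on a saturated chain carbon bound to a sulfur. The six-membered aromatic ring of carbon only thus disappears from this side chain, a feature compound 3 shares with compound 2. A modest loss of potency is expected here, by a step of a 2.2-fold higher number from compound 1 to compound 3 (0.34 log units; beyond the scatter), because compound 2, which also lacks that ring on the sulfur chain, gives 38 nM. Compound 3 is therefore estimated at 28 nM, within a range from 9 nM to 90 nM.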

Compound 3, half-maximal effective concentration: 51 nM
The estimate for compound 3 lay 1.8-fold (0.26 log units) below the measured number; low and high end bracket the measured number.
By their numbers in this assay, from the lowest: compound 1; then compounds 2 and 3 (each within the scatter of the next).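

Within the shared core of compound 1, on a saturated chain carbon bound to a sulfur, 1H-1,2,4-triazol-5-yl in place of 3-carbamoylphenyl gives a 4.0-fold higher number from compound 1 to compound 3 (0.60 log units; beyond the scatter) in this assay. This pair differs in this one place only, so it gives a direct reading of the group on the sulfur chain: the change costs a modest amount of potency, but agonist activity survives without the six-membered aromatic ring of carbon only or the carbamoyl group. Nothing shown here explains the loss.

From the compounds shown here alone, the change replaces the ring and the carbamoyl group together, so the contribution of each remains open. A plain benzyl group or a 3-carboxybenzyl group on the same sulfur would help to separate them.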